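Chain shortening and tolerated concentration on HEL cells

The source may hold more compounds than are shown below. What is called first, only, known or untested is meant among the compounds shown, and "the series" means these compounds.

Measured compounds:
- compound 1, `CCCCCCCc1cc2cn(COCCO)c(O)nc-2n1`, 119000 nM in a functional assay on HEL cells (Homo sapiens); a lower number here means that less compound is tolerated, a higher number that more compound is tolerated
- compound 2, `CCCCCCCCCCCc1cc2cn(COCCO)c(=O)nc2o1`, 132000 nM in this assay
- compound 3, `CCCCCCCCCCCc1cc2cn(COCCO)c(O)nc-2n1`, 41000 nM in this assay

Compound 1 and compound 3 share one core and differ only in the chain on the ring. That change is hydrogen in place of butyl on a saturated chain carbon, seven bonds along the chain from an aromatic carbon, and it makes the step of a 2.9-fold higher number from compound 3 to compound 1 (0.46 log units; beyond the scatter), so the shorter chain lets the cells tolerate more compound.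

Compound 2 carries a different core with the long chain; how the two cores differ is not broken down here. Its value stands close to that of compound 1 and clearly apart from that of compound 3.

Compound 4, `CCCCCCCc1cc2cn(COCCO)c(=O)nc2o1`, is compound 2 with the same kind of change, (hydrogen in place of butyl on a saturated chain carbon, seven bonds along the chain from an aromatic carbon). Because the same shortening gave a 2.9-fold higher number from compound 3 to compound 1 (0.46 log units; beyond the scatter) on the other core, a step of about the same size is expected here, a 2.5-fold higher number from compound 2 to compound 4 (0.40 log units; beyond the scatter). The expected value for compound 4 in this assay is therefore 330000 nM, with a likely range from 150000 nM to 750000 nM; the cores differ, so this rests on one measured step only.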

Compound 4, half-maximal cytotoxic concentration: 140000 nM
Compound 4: middle estimate off by 2.4-fold (0.37 log units), on the high side, outside the stated range (below it).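

In this assay, the same shortening of the chain on the other core gives a 1.1-fold higher number from compound 2 to compound 4 (0.03 log units; within the scatter), so on this core the step cannot be told apart from the usual scatter of repeated measurements. Set beside the earlier step, this shows that the change does not carry over from one core to the other at the same size: the same change on two cores in this assay, a 2.9-fold higher number (0.46 log units; beyond the scatter) from compound 3 to compound 1 and a 1.1-fold higher number (0.03 log units; within the scatter) from compound 2 to compound 4, 2.7-fold (0.44 log units) apart, beyond the scatter of two such steps

A step read on one core is therefore a poor guide to the other core in this series, but with a single pair of compounds on each core, this does not show what in the cores sets the two steps apart or whether the gap would hold for other changes to the chain.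

The compounds shown leave open how a nonyl chain or a longer chain would behave on either core, and so whether the tolerated concentration follows chain length in any steady way. They also leave open what an amine or a carboxylic acid at the end of the chain would do on each core.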